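Swapping the Dihydroxyphenyl for a Fluorophenyl

The source may hold more compounds than are shown below. What is called first, only, known or untested is meant among the compounds shown, and "the series" means these compounds.

Measured so far:
compound 1 `COc1cc(OC)c(OC)cc1/C=C/C(=O)c1cc(Cc2ccccc2)cc(Cc2ccccc2)c1` gives 23300 nM
compound 2 `COc1cc(OC)c(OC)cc1/C=C/C(=O)c1ccc(O)cc1O` gives 33800 nM
compound 3 `COc1cc(OC)c(C(=O)/C=C/c2cc(OC)c(OC)cc2OC)c(OC)c1` gives 51400 nM

All three numbers come from a functional assay on MCF7 cells (Homo sapiens) for inhibition, read by MTT assay, with a stated time of 72 h (a lower number here means a stronger inhibitor, a higher number a weaker inhibitor), and all three sit close together. Compound 2 stands second highest of the three, yet its distance to compound 1 and its distance to compound 3 both fall within the usual scatter, so no order among them can be claimed. The next compound, compound 4 `COc1cc(OC)c(OC)cc1/C=C/C(=O)c1ccc(F)cc1`, has not yet been tested. It differs from compound 2 in one place: 4-fluorophenyl in place of 2,4-dihydroxyphenyl on a carbonyl carbon. Among the measured compounds shown here, no measured pair shows the effect of such a change, so nothing supports a step beyond the scatter in either direction. Compound 4 is therefore expected near compound 2, at about 30000 nM (range 10000 nM to 90000 nM), an expected step of a 1.1-fold lower number from compound 2 to compound 4 (0.05 log units; within the scatter).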

Compound 4, half-maximal inhibitory concentration: 30000 nM
Estimate against measurement, compound 4: no gap at the digits printed, and the stated range covers the measured number.
By their numbers in this assay, from the lowest: compounds 1, 4, 2 and 3 (each within the scatter of the next, the first and the last beyond it).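

In this assay putting 4-fluorophenyl in place of 2,4-dihydroxyphenyl on a carbonyl carbon gives a 1.1-fold lower number from compound 2 to compound 4 (0.05 log units; within the scatter) for this first readable pair. The group that leaves carries 2 hydrogen-bond donors and 2 acceptors and the group that enters carries 0 of each, yet this pair shows no readable difference at this position. No measurement offered here explains that result. Still open, from the compounds shown here alone, is whether a phenyl ring carrying an amine or a carboxylic acid at this place would move the number beyond the scatter.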